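The compounds below may be only part of what the source reports. "The series", "measured", "known", "first", "only" and "open" are said of these compounds alone.

Measured so far:
- compound 1, `O=C(CCCCCCc1ccc(F)cc1)N1CCCC1`: 8000 nM
- compound 2, `COC(=O)c1cccc(CCCCCCC(=O)N2CCCC2)c1`: > 100000 nM

Among the compounds with values here, compound 1, `O=C(CCCCCCc1ccc(F)cc1)N1CCCC1`, is the only member of the series with a number in an assay on HEK293 cells for inhibition of N-acylethanolamine-hydrolyzing acid amidase (Rattus norvegicus), read by LC-MS, with a stated time of 30 min (on this read-out higher numbers stand for weaker inhibition and lower numbers for stronger inhibition), where compound 1 gives 8000 nM. Compound 2, `COC(=O)c1cccc(CCCCCCC(=O)N2CCCC2)c1`, returns only a limit in this assay, > 100000 nM, and sits at the limit of > 100000 nM in this assay, at which 1 of the 2 values shown sits. Within the data shown here, with one number and one limit, no step between measured compounds can be sized, and the two values show only that compound 1 is placed where compound 2 is not.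

Compound 3, `CCCc1ccc(CCCCCCC(=O)N2CCCC2)cc1`, is the next candidate for this assay. Its change from compound 1 is propyl in place of fluoro on an aromatic carbon. Nothing measured in the series bears on a swap of this kind, so the expectation rests on compound 1 alone. The step is expected to stay small, within or close to the scatter, with no firm direction: the estimated step from compound 1 to compound 3 is a 1.6-fold lower number from compound 1 to compound 3 (0.20 log units; within the scatter). Compound 3 is therefore estimated at 5000 nM in this assay, with a range from 1500 nM to 25000 nM.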

Compound 3, half-maximal inhibitory concentration: > 100000 nM
Compound 3 gave a limit, no number; the forecaster's own chance of this, stated with the estimate: 15%; at least 20-fold (1.30 log units) between middle value and limit.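

In this assay, within the data shown here, propyl in place of fluoro on an aromatic carbon, para to a large group, gives an at least 12-fold higher number from compound 1 to compound 3 (1.09 log units; beyond the scatter), the first step that can be sized at all. On these data alone, compound 3 returns > 100000 nM, which is a limit and not a number, so the printed step is a lower bound and its full size stays unknown. The position is therefore not indifferent to the group it carries: a change from one fluorine to three carbons is enough to take the core of compound 1 from a measurable value to the limit, and the series now sits mostly there: the limit of > 100000 nM in this assay, at which 2 of the 3 values shown sit.

The compounds shown do not tell whether this outcome follows the length of the group, as neither a methyl nor an ethyl at this place is among them, nor whether it is specific to a chain rather than to any group larger than fluoro, as a chloro or a methoxy is also absent. They also leave open whether a bare hydrogen, an amine or a carboxylic acid at this position would give a number, and whether any group here would improve on compound 1.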